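A few compounds are considered here, and "the series" means these few. Any claim that something is new, unique, unknown or untested is made for them only; others in the source may bear on it.

Compound 1 `O=C(c1ccc(-c2ccc(O[C@H]3O[C@H](CO)[C@@H](O)[C@H](O)[C@@H]3O)cc2)cc1)N1CCOCC1`: > 1 h, a limit
Compound 2 `N#Cc1ccc(-c2ccc(O[C@H]3O[C@H](CO)[C@@H](O)[C@H](O)[C@@H]3O)cc2)cc1`: > 1 h, a limit

In an ADME assay (liver) for metabolic stability, with Liver microsome (Rattus norvegicus) as the target, read by LC-MS, using microsomes, with a stated time of 10 min, tested at 2 uM (a lower number here means that the compound disappears faster, a higher number that the compound lasts longer), compound 2 gives > 1 h, which is a limit of the assay and not a number. The whole data set so far comes down to the limit of > 1 h in this assay, at which 2 of the 2 values shown sit.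

Compound 3 `N#Cc1ccc(-c2ccc(O[C@H]3O[C@H](CO)[C@@H](O)[C@H](O)[C@@H]3O)c(Cl)c2)cc1` differs from compound 2 in one place: chloro in place of hydrogen on an aromatic carbon. This is chloro in place of hydrogen on an aromatic carbon, ortho to a large group.

Among the compounds with values here, the only measured step is a step that the two limits leave unreadable from compound 1 to compound 2. That change was cyano in place of (morpholin-4-yl)carbonyl on an aromatic carbon, and it gives no size to carry forward. Within the data shown here, no measured step involves a chloro group, so the data offer no direct guide to this change. The expectation therefore rests on compound 2 and its > 1 h alone, and no step beyond the scatter is expected. The assay may well report only a limit again.

The estimated change is a step that the limit leaves unreadable from compound 2 to compound 3. For compound 3 the expected half-life is 1.5 h, with an estimated range from 0.7 h to 3 h.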

Compound 3, half-life: > 1 h
Compound 3 ended at the assay's limit; the forecaster's own chance of this, stated with the estimate: 75%; the middle value is on the limit's open side.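

In this assay compound 3 gives > 1 h, which is a limit of the assay and not a number. Within the data shown here, compound 2 also stands at a limit, so no step from it to compound 3 can be read. On these data alone, what remains open is how long compound 1, compound 2 and compound 3 actually last, and whether they differ at all: the limit of > 1 h in this assay, at which 3 of the 3 values shown sit.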